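Aryl hydrazone variation in a diaryl ether urea series

The source may report more compounds than this note shows. Statements on the series, on what has been measured and on what is new or still open speak of the compounds shown alone.

Measured so far:
compound 1, `CN(C)CCn1cnnc1-c1cc(Oc2ccc(NC(=O)N/N=C/c3c(O)ccc4ccccc34)cc2F)ccn1`; in a functional assay on U-87MG ATCC cells (Homo sapiens) for cytotoxicity, read by MTT assay, with a stated time of 72 h (a higher number here means a weaker inhibitor, a lower number a stronger inhibitor), compound 1 gives 620 nM.
compound 2, `CN(C)CCn1cnnc1-c1cc(Oc2ccc(NC(=O)N/N=C/c3cccc(Br)c3)cc2F)ccn1`; in this assay compound 2 gives 830 nM.

Compound 2 cannot be separated from compound 1 on these numbers, since the step of a 1.3-fold higher number from compound 1 to compound 2 (0.13 log units; within the scatter) lies within the scatter. Compound 3, `CN(C)CCn1cnnc1-c1cc(Oc2ccc(NC(=O)N/N=C/c3ccc(O)c(F)c3)cc2F)ccn1`, differs from compound 2 by 3-fluoro-4-hydroxyphenyl in place of 3-bromophenyl on a carbon with a double bond to nitrogen. Among the measured compounds shown here, the only step that bears on this change is a 1.3-fold higher number from compound 1 to compound 2 (0.13 log units; within the scatter), where swapping the aryl group on the carbon with a double bond to nitrogen left the number essentially unchanged. No step beyond the scatter is therefore expected in this assay, the expected step being a 1.2-fold lower number from compound 2 to compound 3 (0.07 log units; within the scatter). For compound 3 the estimate in this assay is 700 nM, with a range of 300 nM to 1600 nM.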

Compound 3, half-maximal inhibitory concentration: > 100000 nM
Compound 3 was reported as a limit; the forecaster's own chance of this, stated with the estimate: 5%; middle value at least 140-fold (2.15 log units) from the limit.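

The aryl group on the carbon with a double bond to nitrogen is not freely exchangeable in this assay: 3-fluoro-4-hydroxyphenyl gives an at least 120-fold higher number from compound 2 to compound 3 (2.08 log units; beyond the scatter), and against 2-hydroxynaphthalen-1-yl the step is an at least 160-fold higher number from compound 1 to compound 3 (2.20 log units; beyond the scatter). The earlier pair showed no separation at this position, so that tolerance does not extend to every aryl group. The result for compound 3 is a limit of the assay, not a number: the limit of > 100000 nM in this assay, at which 1 of the 3 values shown sits.

Compound 1 also carries a hydroxyl, so the compounds shown do not separate the contributions of the hydroxyl and the fluorine in compound 3. Open, from the compounds shown here alone, is how a phenyl group carrying only the fluorine or only the hydroxyl, or a methyl ether of that hydroxyl, would read.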